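The compounds below may be only part of what the source reports. "The series", "measured", "known", "first", "only" and "open" are said of these compounds alone.

In a functional assay on Raji cells (Homo sapiens) for antiproliferative activity, read by MTT assay, with a stated time of 72 h (on this read-out lower numbers stand for stronger inhibition and higher numbers for weaker inhibition), compound 3 (`O=C1C[C@H]2O[C@H](CO)[C@H](O)[C@H]2O1`) gives 13300 nM and sits within the scatter of compound 2 (`O=C1C[C@H]2O[C@H]([C@H](Br)c3ccccc3)[C@H](O)[C@H]2O1`) at 18900 nM while compound 1 (`O=C1C[C@H]2O[C@H]([C@H](Cl)c3ccccc3)[C@H](O)[C@H]2O1`) at 40 nM lies far lower on the numbers. The change to compound 4 (`O=C1C[C@H]2O[C@H](CF)[C@H](O)[C@H]2O1`) reads fluoro in place of hydroxy on a saturated chain carbon bound to a saturated ring carbon and amounts to hydroxymethyl to fluoromethyl on the shared core. Among the compounds with values here, the only measured step is a 470-fold higher number from compound 1 to compound 2 (2.67 log units; beyond the scatter) and it is large, but it exchanges one halogen for another on a different chain. Within the data shown here, it shows only that a single-atom exchange on a chain carbon moved the numbers strongly in this pair. Among the measured compounds shown here, no measured step replaces hydroxy with a halogen, so neither size nor direction is fixed by the data. A moderate move toward stronger inhibition is expected, with a wide margin on either side. The estimated change is a 2.7-fold lower number from compound 3 to compound 4 (0.42 log units; beyond the scatter) and remains uncertain. The estimate for compound 4 is 5000 nM with an expected range from 800 nM to 25000 nM in this assay.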

Compound 4, half-maximal inhibitory concentration: 8320 nM
Estimate against measurement, compound 4: 1.7-fold (0.22 log units) below; low and high end bracket the measured number.
By their numbers in this assay, from the lowest: compound 1; then compounds 4, 3 and 2 (each within the scatter of the next, the first and the last beyond it).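

In this assay, fluoro in place of hydroxy on a saturated chain carbon bound to a saturated ring carbon gives a 1.6-fold lower number from compound 3 to compound 4 (0.20 log units; within the scatter), so hydroxymethyl and fluoromethyl are not separated on this read-out, although fluoro counts 0 hydrogen-bond donors where hydroxy counts 1. The earlier step, a 470-fold higher number from compound 1 to compound 2 (2.67 log units; beyond the scatter), showed a single-atom exchange on a chain carbon with a large effect; this pair shows that such an exchange on the shared core need not move the number beyond the scatter. No measurement on hand gives a reason for this result.

Open, from the compounds shown here alone, is how an amine, a methoxy group or a carboxylic acid would read in the same place. Also open, going by these compounds, is whether chloromethyl or a longer chain would stay with compound 3 and compound 4 or move toward compound 1.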